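The source may report more compounds than this note shows. Statements on the series, on what has been measured and on what is new or still open speak of the compounds shown alone.

Compound 1, `O=C(O)c1ccccc1-c1ccc(CCc2ncc(Cc3ccccc3F)[nH]2)cc1`, is the reference point of this short series. In an in vitro functional assay on cells for agonist activity at Bombesin receptor subtype-3 (Mus musculus), read by luminescence and calcium flux (on this read-out higher numbers stand for an effect only at larger amounts of compound and lower numbers for an effect already at smaller amounts), compound 1 gives 9.5 nM, which is the lowest of the two numbers in hand. For the measured compounds named here, its only measured neighbour is compound 2, `O=C(O)c1ccccc1-c1ccc(CCc2ncc(CC3CC3)[nH]2)cc1`, which in this assay gives 72 nM; the step of a 7.6-fold higher number from compound 1 to compound 2 (0.88 log units; beyond the scatter) shows that exchanging the whole aromatic group on that saturated chain carbon for a small saturated ring is felt, though only modestly.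

Compound 3, `COc1ccccc1Cc1cnc(CCc2ccc(-c3ccccc3C(=O)O)cc2)[nH]1`, keeps the aromatic group in place and alters only its single substituent: methoxy in place of fluoro on an aromatic carbon. Going by the values given here, no measured pair in this set isolates a change of that kind, so the step from compound 1 to compound 2 is the only guide, and it concerns a much larger alteration than the one at hand. Because that larger change cost only a 7.6-fold higher number from compound 1 to compound 2 (0.88 log units; beyond the scatter), a smaller adjustment at the same region is expected to move the number less, most likely within the scatter or slightly upward. Compound 3 is therefore expected to give about 16 nM in this assay, somewhere between 5 nM and 50 nM, a step of a 1.7-fold higher number from compound 1 to compound 3 (0.23 log units; within the scatter) from compound 1.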

Compound 3, half-maximal effective concentration: 163 nM
Beside the measured number, compound 3's estimate is 10-fold (1.01 log units) below it; the measured number lies above the stated range.
By their numbers in this assay, from the lowest: compound 1; then compound 2; then compound 3.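

In this assay this position proves far less tolerant than the earlier pair suggested: exchanging fluoro for methoxy, ortho to a large group, adds only a small substituent yet gives a 17-fold higher number from compound 1 to compound 3 (1.23 log units; beyond the scatter) and is a large step, whereas replacing the entire 2-fluorophenyl with cyclopropyl gave only a 7.6-fold higher number from compound 1 to compound 2 (0.88 log units; beyond the scatter) and was a modest one. An aromatic ring on this chain carbon therefore does not by itself secure the lower number, since 2-methoxyphenyl in place of cyclopropyl gives a 2.3-fold higher number from compound 2 to compound 3 (0.35 log units; beyond the scatter) and so moves the number further up, not down. Nothing measured here accounts for the size of these steps.

On these data alone, how an unsubstituted phenyl, or a chloro, methyl or hydroxyl group at the same place, would stand against compound 1 remains open, so it cannot be told whether fluoro itself favours the lower number or methoxy alone raises it. Also open, as far as these compounds go, is whether methoxy elsewhere on the ring, or a longer chain carrying the 2-methoxyphenyl group, would produce a step of similar size.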